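Swapping a furan for a pyrrole on the shared core

A few compounds are considered here, and "the series" means these few. Any claim that something is new, unique, unknown or untested is made for them only; others in the source may bear on it.

Measured compounds in an assay on CHO cells for displacement of a labelled ligand from adenosine receptor A1 (Homo sapiens), read by scintillation counting, with a stated time of 120 min, tested at 1 uM; on this read-out higher numbers stand for more inhibition at the one concentration tested (going by the name of the read-out) and lower numbers for less inhibition:
- Compound 1, `Cc1nc2sc(-c3ccccc3)nc2c(=O)[nH]1`, gives 11%.
- Compound 2, `Cc1nc2sc(-c3ccc(C(=O)O)cc3)nc2c(=O)[nH]1`, gives 1%.
- Compound 3, `Cc1nc2sc(-c3ccco3)nc2c(=O)[nH]1`, gives 37%.

Compound 3 stands highest of the three numbers. Its nearest neighbour is compound 1, and its furthest is compound 2; both of these gaps lie beyond the usual scatter of this measurement. For the measured compounds named here, the only step between measured compounds that differ in one place is a number 10 percentage points lower from compound 1 to compound 2 (within the scatter), which lies within the scatter and says little about changing the ring on the core.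

Compound 4, `Cc1nc2sc(-n3cccc3)nc2c(=O)[nH]1`, has not yet been measured. It differs from compound 3 in one place: 1H-pyrrol-1-yl in place of furan-2-yl on an aromatic carbon. Both the group that leaves and the group that enters are a five-membered aromatic ring with a single hetero atom, so the change is small in size. Going by the values given here, no measured step covers this kind of swap, and the one step that is known does not bear on it. Because compound 3 gives 37% and the change is modest, the step of a number 10 percentage points lower from compound 3 to compound 4 (within the scatter) is expected to be small, with a slight lean downward. Compound 4 is therefore estimated at 27% in this assay, in a range from 5% to 50%.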

Compound 4, a percentage reported as inhibition, at one concentration (the size of the read-out at that concentration, not a potency): 1%
Estimate against measurement, compound 4: 26 percentage points above, outside the stated range (below it).
By their numbers in this assay, from the lowest: compounds 2, 4 and 1 (each within the scatter of the next); then compound 3.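

In this assay, putting 1H-pyrrol-1-yl in place of furan-2-y on this aromatic carbon gives a number 36 percentage points lower from compound 3 to compound 4 (beyond the scatter) and shows that the position can respond strongly even when one five-membered aromatic ring with a single hetero atom replaces another. The two groups have the same counts of heavy atoms, hydrogen-bond donors and hydrogen-bond acceptors, and neither carries a net charge, so these counts do not separate them; the names show instead that one ring holds oxygen and is joined through a carbon, while the other holds nitrogen and is joined through that nitrogen. No evidence is available to say what lies behind this step.

The compounds shown change the hetero atom and the point of attachment together, so they leave open which of the two matters here; a 1H-pyrrol-2-yl group, joined through carbon, would help to separate them. A thiophen-2-yl group, or a furan-2-yl ring carrying a methyl group, would further show how much change this position accepts while keeping the number seen for compound 3.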